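Removing One Double Bond from Compound 2

The source may hold more compounds than are shown below. What is called first, only, known or untested is meant among the compounds shown, and "the series" means these compounds.

Among the measured compounds shown here, in a functional assay on DU-145 cells (Homo sapiens) for cytotoxicity, read by MTT assay, with a stated time of 24 h (a higher number here means a weaker inhibitor, a lower number a stronger inhibitor), compound 2 (`CCCCCCCC/C=C\CCCCCCCC(=O)Nc1nnc(S[C@@H]2O[C@H](COC(C)=O)[C@H](OC(C)=O)[C@H](OC(C)=O)[C@H]2OC(C)=O)s1`) gives 42000 nM as the only number in this small set. Compound 1 (`CCCCCCCCCCCCCCCCCC(=O)Nc1nnc(S[C@@H]2O[C@H](CO)[C@H](O)[C@H](O)[C@H]2O)s1`) gives "not active" (no number reported) without a number, and compound 3 (`CCCCCCCC/C=C\CCCCCCCC(=O)Nc1nnc(S[C@@H]2O[C@H](CO)[C@H](O)[C@H](O)[C@H]2O)s1`) gives "not active" (no number reported) in the same way. For the measured compounds named here, a single number cannot show a trend, and no measured pair yet reveals how far one structural change can move the result.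

Compound 4 (`CCCCCCCCCCCCCCCCCC(=O)Nc1nnc(S[C@@H]2O[C@H](COC(C)=O)[C@H](OC(C)=O)[C@H](OC(C)=O)[C@H]2OC(C)=O)s1`) has not yet been measured. The change from compound 2 to compound 4 is decyl in place of dec-1-en-1-yl on a saturated chain carbon, seven bonds along the chain from a carbonyl carbon and, in words, it places decyl in place of dec-1-en-1-yl on a saturated chain carbon, seven bonds along the chain from a carbonyl carbon. The double bond of that chain is lost.

With compound 2 at 42000 nM as the only numerical anchor, no shift beyond the usual scatter is expected in this assay for this change, with at most a slight lean towards a weaker result. The estimated step of a 1.2-fold higher number from compound 2 to compound 4 (0.08 log units; within the scatter) is therefore expected to be small. A result without a number also remains possible. The estimate for compound 4 is 50000 nM with an expected range of 20000 nM to 120000 nM for this measurement.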

Compound 4, half-maximal inhibitory concentration: 31200 nM
Estimate against measurement, compound 4: 1.6-fold (0.20 log units) above, within the range that was stated.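

In this assay, among the compounds shown here, compounds 2 and 4 form the first measured pair that differs in one place, and the result is a 1.3-fold lower number from compound 2 to compound 4 (0.13 log units; within the scatter). On a saturated chain carbon, seven bonds along the chain from a carbonyl carbon, decyl in place of dec-1-en-1-yl therefore gives a result that cannot be told apart from that of compound 2, so in this pair the double bond of the chain can be lost without a shift beyond the usual scatter. No supporting measurement in this set bears on why the two compounds read alike.

The same change cannot be read as a step in the compounds with free hydroxyl groups: compound 3 gives "not active" (no number reported) and compound 1 gives "not active" (no number reported), so neither has a number to compare. The compounds shown also leave open what a different group at this place would do, such as a shorter octyl chain, a longer chain, or a chain ending in an amine or a carboxylic acid.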